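This account rests on a few compounds, and the source may have more. Where it says the series, first, only, none or still open, it means among the compounds named here.

Compound 1 `Oc1ccccc1CNc1ccc(-c2ccccc2)cc1`: 1820 nM
Compound 2 `Cc1ccc(-c2ccc(NCc3ccccc3O)cc2)cc1`: 3790 nM
Compound 3 `CC(C)(C)c1ccc(-c2ccc(NCc3ccccc3O)cc2)cc1`: "not active" (no number reported)

Among the measured compounds shown here, in a functional assay on Jurkat cells (Homo sapiens) for activation, with a stated time of 24 h (on this read-out higher numbers stand for an effect only at larger amounts of compound and lower numbers for an effect already at smaller amounts), compound 1 gives 1820 nM and compound 2 gives 3790 nM; the single measured step between them, a 2.1-fold higher number from compound 1 to compound 2 (0.32 log units; beyond the scatter), goes with a methyl in place of hydrogen on an aromatic carbon. Compound 3 stands apart: in this assay it is reported as not active, with no number to place it against compounds 1 and 2. Compound 4 `Oc1ccccc1CNc1ccc(-c2ccc(C(F)(F)F)cc2)cc1` differs from compound 3 by trifluoromethyl in place of tert-butyl on an aromatic carbon. For the measured compounds named here, no measured step covers this change, and the step from compound 1 to compound 2 touches only the same position, not the groups involved. On this basis compound 4 is expected to give a number near 6000 nM, with a range of 2000 nM to 25000 nM.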

Compound 4, half-maximal effective concentration: "not active" (no number reported)
Compound 4: no number reported; there is nothing to compare the estimate with.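

Among the compounds shown here, with no number for compound 3 or compound 4 in this assay, no step between them can be read. The compounds shown leave open how either compares with compound 1 or compound 2, and no evidence bears on this result.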